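Pyridin-2-yl in Place of Methyl on a Core with Low Numbers

This account rests on a few compounds, and the source may have more. Where it says the series, first, only, none or still open, it means among the compounds named here.

Compound 1 `Nc1n[nH]c2cc(-c3ccccn3)[nH]c(=O)c12`: 2%
Compound 2 `Cc1cc2c(c(N)nn2C)c(N2CC[C@H](O)C2)n1`: 7%
Compound 3 `Cc1cc2nn(-c3ccccc3)c(N)c2c(=O)[nH]1`: 5%

In an assay on isolated protein for inhibition of RAC-alpha serine/threonine-protein kinase (Homo sapiens), read by mobility shift assay, tested at 30 uM (on this read-out higher numbers stand for more inhibition at the one concentration tested (going by the name of the read-out) and lower numbers for less inhibition), compound 3 gives 5%, the second highest of the three numbers. The nearest number belongs to compound 2 and the furthest to compound 1, and both lie within the scatter of compound 3, so the three measured compounds cannot be told apart on this read-out. Compound 4 `Nc1c2c(=O)[nH]c(-c3ccccn3)cc2nn1-c1ccccc1` has not been measured. It differs from compound 3 in one place: pyridin-2-yl in place of methyl on an aromatic carbon. Among the measured compounds shown here, no step between measured compounds is available to guide the expectation. The step of no change at the digits printed from compound 3 to compound 4 (within the scatter) is expected to stay within the scatter, with no clear direction, because compound 1 gives 2% while carrying a pyridin-2-yl of its own. Compound 4 is therefore expected to give 5%, estimated between 0% and 15%.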

Compound 4, a percentage reported as inhibition, at one concentration (the size of the read-out at that concentration, not a potency): 4%
For compound 4 the middle estimate is 1 percentage points above the measured one; the measured number falls inside the stated range.
By their numbers in this assay, from the lowest: compounds 1, 4, 3 and 2 (each within the scatter of the next).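

In this assay, pyridin-2-yl in place of methyl on this aromatic carbon, next to the ring nitrogen, gives a number 1 percentage points lower from compound 3 to compound 4 (within the scatter). Among the compounds shown here, this is the first direct comparison at this position, and it shows that an aromatic ring can stand here in place of methyl without the number leaving the scatter. No evidence is at hand that bears on this result.

On these data alone, whether an amine or a carboxylic acid at this position would move the number beyond the scatter remains open. Also open, as far as these compounds go, is whether any group here can do so while the phenyl stays on the shared core.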